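The source may hold more compounds than are shown below. What is called first, only, known or untested is meant among the compounds shown, and "the series" means these compounds.

Measured compounds:
- compound 1 `CCCCc1nc(C(C)C)c(CC(=O)OCC(F)(F)F)c(=O)n1Cc1ccc(-c2ccccc2-c2noc(=O)[nH]2)cc1` — in an ADME assay on microsomes from liver (Homo sapiens) for metabolic stability, with a stated time of 30 min (on this read-out higher numbers stand for a more stable compound and lower numbers for a less stable compound), compound 1 gives "not determined" (no result reported)
- compound 2 `CCCCCOC(=O)Cc1c(C(C)C)nc(CCCC)n(Cc2ccc(-c3ccccc3-c3noc(=O)[nH]3)cc2)c1=O` — in this assay compound 2 gives 10.6%

Among the measured compounds shown here, compound 2 holds the only number in this assay; compound 1 has no result, so nothing can be said of how the two stand against each other, and no step between measured compounds exists to lean on. Compound 3 `CCCCc1nc(C(C)C)c(CC(=O)OCC(C)C)c(=O)n1Cc1ccc(-c2ccccc2-c2noc(=O)[nH]2)cc1` differs from compound 2 in one place: isopropyl in place of butyl on a saturated chain carbon bound to an oxygen next to a carbonyl group. With a single number to start from, the expectation for compound 3 rests on compound 2 alone, which gives 10.6% in this assay. The step is expected to be small, in no clear direction, and not beyond the usual scatter of this assay a number 3.4 percentage points higher from compound 2 to compound 3 (within the scatter). Compound 3 is therefore estimated at 14% in this assay, with a plausible range from 3% to 35%.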

Compound 3, percent of the compound remaining: 8.8%
For compound 3 the middle estimate is 5.2 percentage points above the measured one; the measured number falls inside the stated range.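

In this assay, among the compounds shown here, the change from pentyloxycarbonyl to isobutoxycarbonyl gives a number 1.8 percentage points lower from compound 2 to compound 3 (within the scatter), the first reading of any change at this place. So on this pair, putting isopropyl in place of butyl on the saturated chain carbon bound to an oxygen next to a carbonyl group leaves the percent remaining within what repeated measurements would show, and branching of this chain separates compound 2 and compound 3 by nothing that can be told from scatter. No measurement given here bears on why this read-out stays as it does.

This single pair says nothing about groups of another kind at this place: a carboxylic acid, an amide or a much longer chain might behave differently in this assay. Compound 1 gives "not determined" (no result reported), so its trifluoroethyl ester offers no comparison with either neighbour.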